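The source may hold more compounds than are shown below. What is called first, only, known or untested is meant among the compounds shown, and "the series" means these compounds.

Of the compounds shown here, three have been tested in a functional assay on P388 cells (Mus musculus) for inhibition; on this read-out higher numbers stand for weaker inhibition and lower numbers for stronger inhibition: compound 1 `C(=C/c1ccc2ccccc2c1)\c1ccoc1`, compound 2 `Cn1ccc2cc(/C=C/c3ccc4ccccc4c3)ccc21` and compound 3 `COc1cc(/C=C/c2ccc(N(C)C)c([N+](=O)[O-])c2)cc(OC)c1OC`. Compound 1 gives > 5000 nM, which is a limit and not a number. Compound 2 gives > 5000 nM, again a limit. Compound 3 gives > 5000 nM, also a limit. For the measured compounds named here, compound 3 therefore stands with the other two, and the whole series so far is described by the limit of > 5000 nM in this assay, at which 3 of the 3 values shown sit. None of the three has yet given a numerical half-maximal inhibitory concentration.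

The next compound is compound 4 `COc1cc(/C=C\c2ccc(N(C)C)c([N+](=O)[O-])c2)cc(OC)c1OC`, and the change from compound 3 is small on paper: the two compounds have the same atoms and bonds and differ only in configuration as drawn: 1 of 1 stereo elements differ; a double bond is drawn E in compound 3 and Z in compound 4. A double bond is drawn E in compound 3 and Z in compound 4, and nothing else differs. Going by the values given here, no step between measured compounds is available as a guide, so the size of this change in this assay has to be estimated. The expectation is nevertheless for a real move towards stronger inhibition, beyond the scatter, though its size remains uncertain. The expected change is an at least 16-fold lower number from compound 3 to compound 4 (1.22 log units; beyond the scatter), and it is counted from a limit. For compound 4 the estimated value is 300 nM, with an expected range from 20 nM to 5000 nM.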

Compound 4, half-maximal inhibitory concentration: > 5000 nM
Compound 4 gave a limit, no number; the forecaster's own chance of this, stated with the estimate: 20%; at least 16-fold (1.22 log units) between middle value and limit.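

As far as these compounds go, compound 3 and compound 4 both give only a limit in this assay, so no step can be read between them, and the effect of their single difference stays unknown: the fact that compounds 3 and 4 differ only in the configuration as drawn.

The compounds shown leave open whether the two double-bond forms differ in this read-out, and which structure would give a number at all: the limit of > 5000 nM in this assay, at which 4 of the 4 values shown sit.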